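The compounds below may be only part of what the source reports. "The series", "measured", "known", "first", "only" and "open" are said of these compounds alone.

Measured in a functional assay on SiHa cells (Homo sapiens) for antiproliferative activity, read by CCK-8 assay, with a stated time of 72 h; on this read-out lower numbers stand for stronger inhibition and higher numbers for weaker inhibition:

- compound 1 `COc1ccc(-c2cncnc2-c2cc(OC)c(OC)c(OC)c2)cc1O`: 2750 nM
- compound 2 `CCSc1ccc(-c2cncnc2-c2cc(OC)c(OC)c(OC)c2)cc1`: 1030 nM
- compound 3 `COc1cc(-c2ncncc2-c2ccc(OC(C)C)cc2)cc(OC)c1OC`: 9970 nM

Among these three, compound 3 has the highest number and so shows the weakest inhibition. The next compound, compound 4 `COc1cc(-c2ncncc2-c2ccc(B(O)O)cc2)cc(OC)c1OC`, keeps the rest of compound 3 and changes a single group: a group of 3 heavy atoms (1 boron, 2 oxygen; no ring) in place of a group of 4 heavy atoms (3 carbon, 1 oxygen; no ring), on an aromatic carbon. The new group sits on an aromatic carbon, para to a large group.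

For the measured compounds named here, two measured steps bear on this. The closer one is a 9.7-fold higher number from compound 2 to compound 3 (0.99 log units; beyond the scatter), which brought in the isopropoxy group that now leaves. The other is a 2.7-fold lower number from compound 1 to compound 2 (0.43 log units; beyond the scatter), which also exchanged a substituent on that outer ring. Both show that such swaps can move the number by a modest amount. Going by the values given here, no measured compound carries a boron group, so the direction is uncertain. Since compound 3 sits at 9970 nM and compound 2 reaches 1030 nM, a move downward seems more likely than one upward. The expected change is a 4.0-fold lower number from compound 3 to compound 4 (0.60 log units; beyond the scatter). For compound 4 the estimated value is 2500 nM, with an expected range from 400 nM to 12000 nM.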

Compound 4, half-maximal inhibitory concentration: 17500 nM
Compound 4: the middle estimate sits 7.0-fold (0.85 log units) below what was measured, outside the stated range (above it).
By their numbers in this assay, from the lowest: compound 2; then compound 1; then compounds 3 and 4 (each within the scatter of the next).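

In this assay, swapping isopropoxy for the boron group, which has 2 hydrogen-bond donors where isopropoxy has 0, gives a 1.8-fold higher number from compound 3 to compound 4 (0.24 log units; within the scatter), so these two groups cannot be told apart at this position. The boron group also falls well short of ethylsulfanyl, with a 17-fold higher number from compound 2 to compound 4 (1.23 log units; beyond the scatter), and the outer ring that carries it does worse than the 3-hydroxy-4-methoxyphenyl ring, with a 6.4-fold higher number from compound 1 to compound 4 (0.80 log units; beyond the scatter), which leaves ethylsulfanyl with the lowest number of the four. Nothing measured here explains these numbers. From the compounds shown here alone, whether an amine or a carboxylic acid on this aromatic carbon would come closer to ethylsulfanyl stays open. So does whether a longer sulfur chain, such as propylsulfanyl, would lower the number further or raise it.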